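This account rests on a few compounds, and the source may have more. Where it says the series, first, only, none or still open, it means among the compounds named here.

In a physicochemical assay for solubility, using the shake flask method, in simulated intestinal fluid, measured as kinetic solubility, with a stated time of 2 h, at 25 degrees C, at pH 6.5 (on this read-out lower numbers stand for lower solubility and higher numbers for higher solubility), compound 1 `COc1ccc(CN2C(=O)c3c(C)nc(-c4nc(C)no4)c(N)c3C2=O)cc1` gives < 5000 nM, which is a limit of the assay and not a number. Compound 2 `Cc1noc(-c2nc(C)c3c(c2N)C(=O)N(Cc2ccccc2F)C3=O)n1` gives < 5000 nM, and this too is a limit, so compound 2 has no exact place on the numbers shown. Compound 2 stands at the limit of < 5000 nM in this assay, at which 2 of the 2 values shown sit. Going by the values given here, the only measured step is a step that the two limits leave unreadable from compound 1 to compound 2, where 2-fluorophenyl takes the place of 4-methoxyphenyl, and it offers no size to carry forward.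

Compound 3 `Cc1noc(-c2nc(C)c3c(c2N)C(=O)N(Cc2ccccc2Cl)C3=O)n1` differs from compound 2 by chloro in place of fluoro on an aromatic carbon, ortho to a large group. Among the compounds with values here, no measured step covers this exchange, and the one step available has no readable size. The working expectation in this assay is therefore no step beyond the scatter, in either direction, and another report as a limit is likely. The expected step is a step that the limit leaves unreadable from compound 2 to compound 3. For compound 3 the estimated value is 2500 nM, with an expected range of 800 nM to 6000 nM.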

Compound 3, solubility: < 5000 nM
Compound 3: a limit, no number (the forecaster's own chance of this, stated with the estimate: 85%); the middle value lies beyond the limit too.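

No new step can be read: in this assay compound 3 is reported only as a limit, as are compound 1 and compound 2, so neither exchange has a size. Left open is where each of the three compounds truly lies, and whether any change on the shared core gives a number rather than this shared limit: the limit of < 5000 nM in this assay, at which 3 of the 3 values shown sit.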